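Swapping the Ester Tail: Ether Chain to Trifluoromethyl

The source may report more compounds than this note shows. Statements on the series, on what has been measured and on what is new or still open speak of the compounds shown alone.

Three compounds sharing one core were tested in an assay on COS-7 cells for inhibition of patatin-like phospholipase domain-containing protein 2 (Mus musculus), tested at 200 uM; a lower number here means less inhibition, a higher number more inhibition at the concentration tested (going by the name of the read-out). Compound 1 `CCCCOC(=O)c1cccc(-c2ccc(OCC)cc2)c1` gives 61%, compound 2 `CCCCCCOC(=O)c1cccc(-c2ccc(OCC)cc2)c1` gives 48%, and compound 3 `CCOc1ccc(-c2cccc(C(=O)OCCOC)c2)cc1` gives 89%. Compound 3 stands highest of the three, with compound 1 nearest and compound 2 furthest away. The step of a number 13 percentage points lower from compound 1 to compound 2 (beyond the scatter) came with ethyl in place of hydrogen on a saturated chain carbon, four bonds along the chain from an oxygen next to a carbonyl group. The step of a number 28 percentage points higher from compound 1 to compound 3 (beyond the scatter) came with methoxy in place of ethyl on a saturated chain carbon, two bonds along the chain from an oxygen next to a carbonyl group, and the step of a number 41 percentage points higher from compound 2 to compound 3 (beyond the scatter) came with methoxy in place of butyl at that same place.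

Compound 4 `CCOc1ccc(-c2cccc(C(=O)OCC(F)(F)F)c2)cc1` has not yet been measured. It differs from compound 3 as follows: trifluoromethyl in place of methoxymethyl on a saturated chain carbon bound to an oxygen next to a carbonyl group. This change again sits on the chain bound to an oxygen next to a carbonyl group, where all three measured steps lie; those steps show that this chain matters, but none of them brings in fluorine, so the direction is uncertain. A modest fall, or no step beyond the scatter, is expected: a number 11 percentage points lower from compound 3 to compound 4 (beyond the scatter). In this assay compound 4 is therefore estimated at 78%, within 55% to 95%.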

Compound 4, a percentage reported as inhibition, at one concentration (the size of the read-out at that concentration, not a potency): 71%
Compound 4: middle estimate off by 7 percentage points, on the high side; low and high end bracket the measured number.
By their numbers in this assay, from the lowest: compound 2; then compounds 1 and 4 (each within the scatter of the next); then compound 3.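

Trifluoromethyl is the first fluorinated group at this place, on a saturated chain carbon bound to an oxygen next to a carbonyl group, and in this assay it does not match methoxymethyl: exchanging one for the other gives a number 18 percentage points lower from compound 3 to compound 4 (beyond the scatter), so compound 3 remains the highest of the four. Trifluoromethyl nevertheless reads better than the longer pentyl, with a number 23 percentage points higher from compound 2 to compound 4 (beyond the scatter), while against propyl the exchange gives a number 10 percentage points higher from compound 1 to compound 4 (within the scatter), so those two groups cannot be told apart here. The ester tail can therefore carry fluorine and keep a sizeable read-out, but the data offer no measurement that explains the order of these groups.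

The compounds shown include only one ether chain, 2-methoxyethyl, and one fluorinated chain, 2,2,2-trifluoroethyl, which leaves open whether a longer ether chain such as 2-ethoxyethyl would keep the read-out of compound 3. Going by these compounds, how a 2,2-difluoroethyl chain, with fewer fluorines, or a 2-hydroxyethyl chain would rank at this place also remains open.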